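Swapping methoxy for trifluoromethyl on the core of compound 3

This account rests on a few compounds, and the source may have more. Where it says the series, first, only, none or still open, it means among the compounds named here.

Measured compounds and values:
compound 1 `COc1ccc2[nH]c(-c3cn(-c4ccccc4)nc3-c3ccccc3)nc2c1` gives 1230 nM
compound 2 `FC(F)(F)c1ccc2[nH]c(-c3cn(-c4ccccc4)nc3-c3ccccc3)nc2c1` gives 5930 nM
compound 3 `COc1ccc2[nH]c(-c3cn(-c4ccccc4)nc3-c3ccc(Cl)cc3)nc2c1` gives 2420 nM

These three compounds were tested in a functional assay on A549 cells (Homo sapiens) for antiproliferative activity, read by MTT assay, with a stated time of 48 h; a lower number here means a stronger inhibitor, a higher number a weaker inhibitor. Compound 2 differs from compound 1 by trifluoromethyl in place of methoxy on an aromatic carbon, and that change brought a 4.8-fold higher number from compound 1 to compound 2 (0.68 log units; beyond the scatter). Compound 3 differs from compound 1 by chloro in place of hydrogen on an aromatic carbon, with a 2.0-fold higher number from compound 1 to compound 3 (0.29 log units; within the scatter), so compound 1 and compound 3 cannot be ordered against each other.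

Compound 4 `FC(F)(F)c1ccc2[nH]c(-c3cn(-c4ccccc4)nc3-c3ccc(Cl)cc3)nc2c1` has not been measured in this assay. Going by the values given here, it differs from compound 3 by trifluoromethyl in place of methoxy on an aromatic carbon, the same change as the one from compound 1 to compound 2, made at the same place. Because the earlier step gave a 4.8-fold higher number from compound 1 to compound 2 (0.68 log units; beyond the scatter), a step of similar size is expected here, which would mean a 4.5-fold higher number from compound 3 to compound 4 (0.66 log units; beyond the scatter). On that basis compound 4 is estimated at 11000 nM in this assay, with a likely range from 5000 nM to 25000 nM. What the measurement actually shows remains to be seen.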

Compound 4, half-maximal inhibitory concentration: 3360 nM
Beside the measured number, compound 4's estimate is 3.3-fold (0.52 log units) above it; the whole stated range lies above it.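

Trifluoromethyl in place of methoxy gave a 1.4-fold higher number from compound 3 to compound 4 (0.14 log units; within the scatter) on the chloro-bearing core in this assay and the size of the earlier step did not carry over from one core to the other: the same change on two cores in this assay, a 4.8-fold higher number (0.68 log units; beyond the scatter) from compound 1 to compound 2 and a 1.4-fold higher number (0.14 log units; within the scatter) from compound 3 to compound 4, 3.5-fold (0.54 log units) apart, beyond the scatter of two such steps. Read from the other side, chloro in place of hydrogen gave a 1.8-fold lower number from compound 2 to compound 4 (0.25 log units; within the scatter) on the trifluoromethyl-bearing core and this step also differed from its counterpart on the methoxy-bearing core: the same change on two cores in this assay, a 2.0-fold higher number (0.29 log units; within the scatter) from compound 1 to compound 3 and a 1.8-fold lower number (0.25 log units; within the scatter) from compound 2 to compound 4, 3.5-fold (0.54 log units) apart, beyond the scatter of two such steps. Both comparisons rest on the same four compounds, so they show that neither change can be carried over at a fixed size within this set, but not why this happens or whether it would hold on any other core.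

The compounds shown leave open whether a bromo or methyl group in place of chloro would alter the trifluoromethyl step in the same way. They also leave open how an amine or a nitrile in place of methoxy would behave on either core.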